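The compounds below may be only part of what the source reports. "The series", "measured", "known", "first", "only" and "open" are said of these compounds alone.

Compound 1 `COc1cc(CC2C(C#N)=C(N)N(c3ccc(S(N)(=O)=O)cc3)C3=C2C(=O)CCC3)ccc1O`: 25 ug/mL
Compound 2 `N#CC1=C(N)N(c2ccc(S(N)(=O)=O)cc2)C2=C(C(=O)CCC2)C1c1ccco1`: > 100 ug/mL

In a functional assay on Ehrlich cells (Mus musculus) for antiproliferative activity, read by trypan blue exclusion, with a stated time of 2 h (a lower number here means a stronger inhibitor, a higher number a weaker inhibitor), compound 1 gives 25 ug/mL. Compound 2 reaches only the assay limit of > 100 ug/mL, a bound rather than a number, as the limit of > 100 ug/mL in this assay, at which 1 of the 2 values shown sits, records. The step of an at least 4.0-fold higher number from compound 1 to compound 2 (0.60 log units; beyond the scatter) marked a clear weakening. Compound 3 `N#CC1=C(N)N(c2ccc(S(N)(=O)=O)cc2)C2=C(C(=O)CCC2)C1c1cccs1` carries thiophen-2-yl in place of furan-2-yl on a saturated ring carbon. Within the data shown here, no measured step covers an exchange of one five-membered heteroaryl for another, so no shift beyond the scatter is expected in this assay, and compound 3 is expected to remain a weak inhibitor near the limit. Compound 3 is estimated at 150 ug/mL (range 60 ug/mL to 400 ug/mL), an expected step that the limit leaves unreadable from compound 2 to compound 3.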

Compound 3, half-maximal inhibitory concentration: 5 ug/mL
Beside the measured number, compound 3's estimate is 30-fold (1.48 log units) above it; the measured number lies below the stated range.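

In this assay the exchange of furan-2-yl for thiophen-2-yl on this saturated ring carbon, a swap of the ring's oxygen for sulfur, gives an at least 20-fold lower number from compound 2 to compound 3 (1.30 log units; beyond the scatter) and so is far from neutral. Compound 2 stands at a limit, so that step is only a bound: the limit of > 100 ug/mL in this assay, at which 1 of the 3 values shown sits. Thiophen-2-yl in place of 4-hydroxy-3-methoxybenzyl gives a 5.0-fold lower number from compound 1 to compound 3 (0.70 log units; beyond the scatter) as well, so the small sulfur heteroaryl, unlike the furan-2-yl, exceeds the benzyl group here. Still open, from the compounds shown here alone, is how a phenyl or a pyrrol-2-yl group would read at this carbon, and whether thiophen-3-yl would match thiophen-2-yl.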